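A few compounds are considered here, and "the series" means these few. Any claim that something is new, unique, unknown or untested is made for them only; others in the source may bear on it.

In an ADME assay on NHDF cells (Homo sapiens) for cytotoxicity, read by MTT assay, with a stated time of 72 h (a higher number here means a weaker inhibitor, a lower number a stronger inhibitor), compound 1 (`COc1cccc(/C=C2\CCC/C(=C\c3ccc(Cl)cc3)C2=O)c1OC`) gives 18600 nM and compound 2 (`COc1cccc(/C=C2\CCC/C(=C\c3cccc(Br)c3)C2=O)c1OC`) gives 23900 nM. For the measured compounds named here, compound 2 therefore stands level with compound 1, the only other measured compound, once the usual scatter of repeat measurements is allowed for.

Compound 3 (`COc1ccc(/C=C2\CCC/C(=C\c3cccc(OC)c3OC)C2=O)cc1`) has 4-methoxyphenyl in place of 3-bromophenyl on a double-bonded chain carbon bound to a double-bonded ring carbon.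

Going by the values given here, one measured step bears on this change, since it altered the group at the same place: a 1.3-fold higher number from compound 1 to compound 2 (0.11 log units; within the scatter). That swap of 4-chlorophenyl for 3-bromophenyl left the number within the scatter, and on that evidence no step beyond the scatter is expected in this assay. The expected step is a 1.2-fold lower number from compound 2 to compound 3 (0.08 log units; within the scatter). Among the compounds with values here, no measured compound carries 4-methoxyphenyl at this place, which leaves the range wide. For compound 3 the estimated value is 20000 nM, with an expected range of 9000 nM to 45000 nM.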

Compound 3, half-maximal inhibitory concentration: 43500 nM
Compound 3: middle estimate off by 2.2-fold (0.34 log units), on the low side; low and high end bracket the measured number.
By their numbers in this assay, from the lowest: compounds 1, 2 and 3 (each within the scatter of the next, the first and the last beyond it).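

In this assay, for the compounds shown here, methoxy in place of chloro on an aromatic carbon gives the first step at this place that clears the usual scatter, a 2.3-fold higher number from compound 1 to compound 3 (0.37 log units; beyond the scatter), though only modestly. 4-Methoxyphenyl in place of 3-bromophenyl, by contrast, stays within the scatter at a 1.8-fold higher number from compound 2 to compound 3 (0.26 log units; within the scatter), so across these compounds this place has so far taken a chloro, bromo or methoxy group on the phenyl ring with only small shifts in the number. Nothing measured here explains the gap between compound 1 and compound 3.

All three compounds carry a substituted phenyl ring at this place. From the compounds shown here alone, how a phenyl ring bearing an amine or a carboxylic acid, or a longer chain in place of the ring, would read in this assay stays open.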